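A few compounds are considered here, and "the series" means these few. Any claim that something is new, unique, unknown or untested is made for them only; others in the source may bear on it.

Measured in a functional assay on NCI-H630 cells (Homo sapiens) for cytotoxicity, read by sulforhodamine B assay, with a stated time of 5 days; a higher number here means a weaker inhibitor, a lower number a stronger inhibitor:
compound 1 `O=C(CCCCCCCc1ccccc1)N[C@H]1CCOC1=O`: > 100000 nM
compound 2 `O=C(CCCCCCCCCCCc1ccccc1)N[C@H]1CCOC1=O`: > 100000 nM

Neither entry is a number. Compound 1 is reported only as a limit, > 100000 nM. Compound 2 is likewise reported only as a limit, > 100000 nM. Among the measured compounds shown here, both compounds therefore stand at the limit of > 100000 nM in this assay, at which 2 of the 2 values shown sit, and no measured step is available.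

Next in the series is compound 3 `O=C(CCCCCCCCCc1ccccc1)N[C@H]1CCOC1=O`, which shares the core of compound 2 and differs from it at one place: phenyl in place of phenethyl on a saturated chain carbon, nine bonds along the chain from a carbonyl carbon. In words, this is phenyl in place of phenethyl on a saturated chain carbon, nine bonds along the chain from a carbonyl carbon.

In this assay, no step beyond the scatter is expected in either direction, since compound 2 is only a limit at > 100000 nM. The estimated step is a number no higher from compound 2 to compound 3 (the limit leaves the size open). For compound 3 the estimate is 100000 nM, with an expected range of 40000 nM to 200000 nM. A report of a limit alone is the expected outcome, rather than a number.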

Compound 3, half-maximal inhibitory concentration: > 100000 nM
Compound 3: a limit, no number (the forecaster's own chance of this, stated with the estimate: 85%); the middle value lies on the limit itself.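

Compound 1, compound 2 and compound 3 are each reported only as a limit in this assay, so no step among them can be read: the limit of > 100000 nM in this assay, at which 3 of the 3 values shown sit.

The compounds shown leave open what number any of the three would give in this assay, and whether the differences in their chains affect that read-out at all.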